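This account rests on a few compounds, and the source may have more. Where it says the series, first, only, none or still open, it means among the compounds named here.

Compound 1 `CC(C)(N)C(=O)N[C@H](COCc1ccccc1)c1nnnn1Cc1ccc(NS(C)(=O)=O)cc1` is one of two compounds tested in an assay on isolated protein for displacement of a labelled ligand from growth hormone secretagogue receptor type 1 (Homo sapiens), with a stated time of 1 h; on this read-out higher numbers stand for weaker inhibition and lower numbers for stronger inhibition. In this assay compound 1 gives > 5000 nM, which is a limit of the assay and not a number. Compound 2 `CC(C)(N)C(=O)N[C@H](COCc1ccccc1)c1nnn(Cc2cccc(NS(C)(=O)=O)c2)n1` sits at a limit as well: in this assay compound 2 gives > 5000 nM. Compound 1 therefore stands at the limit of > 5000 nM in this assay, at which 2 of the 2 values shown sit, with no numbered value anywhere in the set. Compound 3 `CCCCNC(=O)CCCn1nnnc1[C@@H](COCc1ccccc1)NC(=O)C(C)(C)N` is not yet measured; it differs from compound 1 by 2-(butylcarbamoyl)ethyl in place of 4-(methanesulfonamido)phenyl on a saturated chain carbon bound to an aromatic nitrogen. Among the measured compounds shown here, with no measured step in this assay to lean on, the expected step is an at least 1.6-fold lower number from compound 1 to compound 3 (0.22 log units; that floor lies within the scatter), toward stronger binding but of uncertain size. Compound 3 is estimated at 3000 nM, within 300 nM to 10000 nM.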

Compound 3, inhibition constant: 1780 nM
For compound 3 the middle estimate is 1.7-fold (0.23 log units) above the measured one; the range from low to high includes it.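

Placing 2-(butylcarbamoyl)ethyl in place of 4-(methanesulfonamido)phenyl on a saturated chain carbon bound to an aromatic nitrogen gives an at least 2.8-fold lower number from compound 1 to compound 3 (0.44 log units; beyond the scatter) in this assay. This position therefore accepts a chain without a ring and still gives measurable binding, and the step is only a floor on the true change. Compound 3 alone carries a number, while the others stop at a limit: the limit of > 5000 nM in this assay, at which 2 of the 3 values shown sit.

As far as these compounds go, it remains open whether the gain comes from the amide, the butyl end or the loss of the ring. A longer chain, or an amine or a carboxylic acid at the chain end, could settle how much of this chain is needed.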